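Piperazine-to-piperidine exchange on the chain of compound 2

This account rests on a few compounds, and the source may have more. Where it says the series, first, only, none or still open, it means among the compounds named here.

Measured so far in a functional assay on CCRF-CEM cells for antagonist activity at C-X-C chemokine receptor type 4 (Homo sapiens), read by calcium flux, with stated times of 25 min and 90 s; a lower number here means a stronger inhibitor, a higher number a weaker inhibitor:
compound 1, `c1ccc2c(c1)CN[C@H](CN(CCCN1CCNCC1)[C@H]1CCCc3cccnc31)C2`, 1150 nM
compound 2, `c1ccc2c(c1)CN[C@@H](CN(CCCN1CCNCC1)[C@H]1CCCc3cccnc31)C2`, 17 nM
compound 3, `c1ccc2c(c1)CN[C@@H](CN(CC[C@@H]1CCCNC1)[C@H]1CCCc3cccnc31)C2`, 161 nM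

Compound 2 gives the lowest number of the three. Compound 1 differs only in configuration, and a 68-fold lower number from compound 1 to compound 2 (1.83 log units; beyond the scatter); this rests on (the fact that compounds 1 and 2 differ only in the configuration as drawn). Compound 3 differs in the chain terminus, and a 9.5-fold higher number from compound 2 to compound 3 (0.98 log units; beyond the scatter).

Compound 4, `c1ccc2c(c1)CN[C@@H](CN(CCC1CCNCC1)[C@H]1CCCc3cccnc31)C2`, carries the change (piperidin-4-yl in place of (piperazin-1-yl)methyl on a saturated chain carbon, two bonds along the chain from an amine nitrogen). The step from compound 2 to compound 3 is the one that bears on it, being a like exchange at the same place, and it raised the number modestly. A step of similar sign is therefore expected, a 4.7-fold higher number from compound 2 to compound 4 (0.67 log units; beyond the scatter), though the isomer differs. Compound 4 is expected to give about 80 nM in this assay, with a likely range from 25 nM to 300 nM.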

Compound 4, half-maximal inhibitory concentration: 150 nM
The estimate for compound 4 lay 1.9-fold (0.27 log units) below the measured number; low and high end bracket the measured number.
By their numbers in this assay, from the lowest: compound 2; then compounds 4 and 3 (each within the scatter of the next); then compound 1.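

In this assay, piperidin-4-yl in place of (piperazin-1-yl)methyl gives an 8.8-fold higher number from compound 2 to compound 4 (0.95 log units; beyond the scatter) and so matches the loss seen with the piperidin-3-yl of compound 3. The point of attachment on the piperidine makes no readable difference at this place, with a 1.1-fold lower number from compound 3 to compound 4 (0.03 log units; within the scatter) on this pair. Nothing at hand gives a cause for these steps. On these data alone, compounds 3 and 4 alter the ring and its attachment together, so the source of the loss stays open. A 3-(piperidin-1-yl)propyl chain would keep the attachment of compound 2 and lose only the second ring nitrogen.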